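Swapping the Aryl Group for a Furan on the Pyridinone Core

A few compounds are considered here, and "the series" means these few. Any claim that something is new, unique, unknown or untested is made for them only; others in the source may bear on it.

Compound 1 `CCOC(=O)c1c(C)[nH]c(=O)c(C#N)c1-c1ccc(C)cc1` and compound 2 `CCOC(=O)c1c(C)[nH]c(=O)c(C#N)c1-c1ccc(Br)cc1` share one core and differ only in the group on the pendant ring. In a functional assay on MCF7 cells (Homo sapiens) for inhibition, read by MTT assay, with a stated time of 24 h (on this read-out lower numbers stand for stronger inhibition and higher numbers for weaker inhibition), compound 1 gives 8000 nM, and compound 2 gives 31800 nM. Among the measured compounds shown here, that step, a 4.0-fold higher number from compound 1 to compound 2 (0.60 log units; beyond the scatter), is the only measured one, and it leaves compound 2 with the highest of the two numbers so far.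

Compound 3 `CCOC(=O)c1c(C)[nH]c(=O)c(C#N)c1-c1ccco1` takes the next step: furan-2-yl in place of 4-bromophenyl on an aromatic carbon. For the measured compounds named here, no measured step involves a furan-2-yl group, so the single step from compound 1 to compound 2 is the only guide, and it shows only that changing the pendant ring moves the number by a modest amount. Compound 3 is therefore expected to show a step of a 2.1-fold lower number from compound 2 to compound 3 (0.33 log units; beyond the scatter), with the direction uncertain and leaning toward a lower number given that compound 2 carries the higher value 31800 nM. The estimate for compound 3 in this assay is 15000 nM, within 4000 nM to 60000 nM.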

Compound 3, half-maximal inhibitory concentration: 17500 nM
The estimate for compound 3 lay 1.2-fold (0.07 log units) below the measured number, within the range that was stated.
By their numbers in this assay, from the lowest: compound 1; then compounds 3 and 2 (each within the scatter of the next).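

Placing furan-2-yl on the carbon opposite the ring nitrogen gives a 1.8-fold lower number from compound 2 to compound 3 (0.26 log units; within the scatter) in this assay and so cannot be told apart from 4-bromophenyl, which shows that the group here need not be a six-membered aromatic ring of carbon only for the number to stay in this range. Among the compounds shown here, the same replacement of 4-methylphenyl gives a 2.2-fold higher number from compound 1 to compound 3 (0.34 log units; beyond the scatter) and leaves compound 1 as the one compound whose number stands clearly lowest among the three. Nothing available here accounts for these differences.

On these data alone, what remains open is whether a thiophene, a pyridine or a saturated cyclohexyl ring would behave like furan-2-yl at this position. As far as these compounds go, it is also open whether an amine or a carboxylic acid on the pendant ring would move the number in either direction.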